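A hydroxyethyl amide in place of a cyclopropyl amide

The compounds below may be only part of what the source reports. "The series", "measured", "known", "first", "only" and "open" are said of these compounds alone.

Values in a functional assay on LNCaP cells (Homo sapiens) for antiproliferative activity; a lower number here means a stronger inhibitor, a higher number a weaker inhibitor
Compound 1 `Cn1ncc(Cl)c1-c1cc(C(=O)N[C@@H]2CN[C@H](CCn3cncn3)C[C@H]2c2ccc(Cl)c(Cl)c2)oc1Cl` gives 60 nM
Compound 2 `Cn1ncc(Cl)c1-c1cc(C(=O)N[C@@H]2CN[C@H](CC(=O)NC3CC3)C[C@H]2c2ccc(Cl)c(Cl)c2)oc1Cl` gives 190 nM

Compound 2 stands at 190 nM as the higher of the two numbers. The change to compound 3 `Cn1ncc(Cl)c1-c1cc(C(=O)N[C@@H]2CN[C@H](CC(=O)NCCO)C[C@H]2c2ccc(Cl)c(Cl)c2)oc1Cl` is 2-hydroxyethyl in place of cyclopropyl on an amide-type nitrogen and leaves the rest of the structure untouched. Going by the values given here, no measured step covers this exchange. Among the compounds with values here, the only measured step, a 3.2-fold higher number from compound 1 to compound 2 (0.50 log units; beyond the scatter) in size, altered a larger part of the same chain, so it serves only as a rough ceiling for a modest move. A small rise in the number is expected, possibly none beyond the scatter. The estimate means a 1.3-fold higher number from compound 2 to compound 3 (0.12 log units; within the scatter) as the expected step. Compound 3 is expected at 250 nM with an estimated range from 90 nM to 700 nM overall.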

Compound 3, half-maximal inhibitory concentration: 40 nM
The estimate for compound 3 lay 6.3-fold (0.80 log units) above the measured number, outside the stated range (below it).
By their numbers in this assay, from the lowest: compounds 3 and 1 (each within the scatter of the next); then compound 2.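

In this assay, the group on the amide-type nitrogen matters: 2-hydroxyethyl in place of cyclopropyl gives a 4.8-fold lower number from compound 2 to compound 3 (0.68 log units; beyond the scatter), so the higher number of compound 2 does not follow from the amide itself. The (2-hydroxyethyl)carbamoyl group and the (1H-1,2,4-triazol-1-yl)methyl group lie within the scatter of each other, at a 1.5-fold lower number from compound 1 to compound 3 (0.18 log units; within the scatter). Nothing available here accounts for the difference between the two amides. On these data alone, it remains open whether the hydroxyl group is needed, and whether a 2-methoxyethyl group, a 2-aminoethyl group or a longer 3-hydroxypropyl chain on that nitrogen would give a similar number.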